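Notes on bromo to fluoro swap in the thiosemicarbazone series

The compounds below may be only part of what the source reports. "The series", "measured", "known", "first", "only" and "open" are said of these compounds alone.

Measured so far:
compound 1 `S=C(N/N=C/c1ccc(Oc2ccc(Cl)cc2)cc1)Nc1ccc(Br)cc1` – 6.24
compound 2 `Cc1cc(Oc2ccc(/C=N/NC(=S)Nc3ccc(Br)cc3)cc2)ccc1Cl` – 7.89
compound 3 `O=[N+]([O-])c1ccc(Oc2ccc(/C=N/NC(=S)Nc3ccccc3)cc2)cc1` – 4.95

In a physicochemical assay for lipophilicity, in phosphate buffer, measured as octanol-water partition, with a stated time of 24 h (on this read-out lower numbers stand for lower lipophilicity and higher numbers for higher lipophilicity), compound 2 gives the highest of the three numbers. Within the data shown here, its nearest neighbour is compound 1, and the step of a number 1.65 log units higher from compound 1 to compound 2 (beyond the scatter) is the only single-point change measured so far; it is large and beyond the scatter. Compound 3 differs from both in more than one place, so only its value stands for comparison, and in this assay compound 3 gives 4.95, the lowest of the set.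

Compound 4 `Cc1cc(Oc2ccc(/C=N/NC(=S)Nc3ccc(F)cc3)cc2)ccc1Cl` is not yet measured. It differs from compound 2 by fluoro in place of bromo on an aromatic carbon. Among the measured compounds shown here, no measured step bears on this particular change: the only step on record concerns methyl in place of hydrogen, not a change at the bromo position. The change exchanges one heavy atom for one heavy atom and leaves donor and acceptor counts as they were, so a step smaller than a number 1.65 log units higher from compound 1 to compound 2 (beyond the scatter) is expected, most likely downward, though a result within the scatter is not excluded. For compound 4 the expected step is a number 0.69 log units lower from compound 2 to compound 4 (beyond the scatter), giving an estimate of 7.2 with a range from 6.6 to 7.8.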

Compound 4, partition coefficient: 6.07
For compound 4 the middle estimate is 1.13 log units above the measured one; measured number below the stated range.
By their numbers in this assay, from the lowest: compound 3; then compounds 4 and 1 (each within the scatter of the next); then compound 2.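

In this assay, among these compounds, the exchange of 4-bromophenyl for 4-fluorophenyl gives a number 1.82 log units lower from compound 2 to compound 4 (beyond the scatter) and is the first measured change at this position, on an aromatic carbon para to a large group. The read-out therefore responds strongly here, although one heavy atom replaces one heavy atom and the donor and acceptor counts of the two groups are the same. The series now holds two large single-place steps, this one and a number 1.65 log units higher from compound 1 to compound 2 (beyond the scatter) at a different place on the shared core, but no supporting measurement accounts for the size of the new step.

Among the compounds shown here, only one matched pair bears on this position, so it remains open whether the same exchange would give a step of similar size in a compound without the methyl group, such as the core of compound 1. Also open is how the read-out would respond at this place to groups outside the bromo and fluoro pair, such as an amine, a carboxylic acid or a longer alkyl chain, since the compounds shown give no reading for any of them.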